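A Carbonyl-Linked Ring in Place of a Pyridinylmethyl Group

The source may hold more compounds than are shown below. What is called first, only, known or untested is meant among the compounds shown, and "the series" means these compounds.

Of the compounds shown here, three built on one shared core have been measured in an assay on HEK293 cells for agonist activity at Toll-like receptor 8 (Homo sapiens), read by a luciferase reporter, with a stated time of 6 h; a lower number here means that less compound is needed, a higher number that more compound is needed for the effect. Compound 1 `CCCCNc1nc(N)nc2c1CCN(Cc1ccccc1)C2` gives 0.4 uM. Compound 2 `CCCCNc1nc(N)nc2c1CN(Cc1ccc(-c3ccccc3)cc1)CC2` gives 0.5 uM. Compound 3 `CCCCNc1nc(N)nc2c1CN(Cc1cccnc1)CC2` gives 0.13 uM, the lowest of the three numbers; its distance from compound 1, the nearest of the other two, and from compound 2, the furthest, both lie beyond the usual scatter of repeated measurements, so compound 3 needs the least material of the three for the effect.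

Compound 4 `CCCCNc1nc(N)nc2c1CN(C(=O)c1cc(C)on1)CC2` has not yet been measured. It differs from compound 3 in a single place: (5-methyl-1,2-oxazol-3-yl)carbonyl in place of (pyridin-3-yl)methyl on an amine nitrogen in a ring. The entering group carries a five-membered aromatic ring with two hetero atoms and three hydrogen-bond acceptors, where the leaving group carried a six-membered aromatic ring with one hetero atom and a single acceptor.

For the measured compounds named here, no measured pair shows what this kind of change does on this core, so the expectation rests only on the spread of the three known numbers and the scatter. A modest rise in the number is expected, a 4.6-fold higher number from compound 3 to compound 4 (0.66 log units; beyond the scatter), though a result within the scatter of compound 3 would not be surprising. For compound 4 the estimate in this assay is 0.6 uM, with a range from 0.15 uM to 3 uM.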

Compound 4, minimum effective concentration: 0.4 uM
Compound 4: middle estimate off by 1.5-fold (0.18 log units), on the high side, and the stated range covers the measured number.
By their numbers in this assay, from the lowest: compound 3; then compounds 1, 4 and 2 (each within the scatter of the next).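

In this assay, for the compounds shown here, placing (5-methyl-1,2-oxazol-3-yl)carbonyl where (pyridin-3-yl)methyl stood on the amine nitrogen in a ring gives a 3.1-fold higher number from compound 3 to compound 4 (0.49 log units; beyond the scatter), the first step on this core that shows what a change at this nitrogen does. The step is modest but beyond the scatter, and it shows that this nitrogen can carry a carbonyl-linked five-membered aromatic ring with the effect still seen, as compound 4 gives 0.4 uM. The change alters the link, the ring size, the hetero atoms and the acceptor count all at once, and nothing available here explains the rise or assigns it to any one of these differences.

Still open, on these data alone, is whether the rise follows the carbonyl link or the ring, a question that a (5-methyl-1,2-oxazol-3-yl)methyl group or a (pyridin-3-yl)carbonyl group on the same nitrogen could help to settle. Also open, as far as these compounds go, is what a simple acetyl group, with no ring at all, would do at this position.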